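A few compounds are considered here, and "the series" means these few. Any claim that something is new, unique, unknown or untested is made for them only; others in the source may bear on it.

Measured compounds:
Compound 1, `CS(=O)(=O)c1ccc(Nc2ncc(F)c(Nc3nc4ccccc4s3)n2)cc1`, gives 2830 nM in a functional assay on PC-3 cells (Homo sapiens) for antiproliferative activity, read by MTT assay, with a stated time of 48 h; on this read-out lower numbers stand for stronger inhibition and higher numbers for weaker inhibition.
Compound 2, `CS(=O)(=O)c1ccc(Nc2nccc(Nc3nc4ccc(F)cc4s3)n2)cc1`, gives 1940 nM in this assay.

Compound 2 stands at the lowest of the two numbers in this assay; its nearest neighbour is compound 1, and the gap between the two values lies within the usual scatter, so no order between them can be read from these data. Compound 3, `CS(=O)(=O)c1ccc(Nc2nccc(Nc3nc4ccccc4s3)n2)cc1`, is not yet measured. It differs from compound 2 in one place: hydrogen in place of fluoro on an aromatic carbon. Within the data shown here, no step between measured compounds of this kind is known, so the size of this change cannot be taken from the data. A step of no more than the scatter, in either direction, is therefore expected in this assay. For compound 3 the expected value in this assay is 2100 nM, with a range from 900 nM to 4800 nM. This estimate means a step of a 1.1-fold higher number from compound 2 to compound 3 (0.03 log units; within the scatter), expected to remain within the scatter.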

Compound 3, half-maximal inhibitory concentration: 1710 nM
The estimate for compound 3 lay 1.2-fold (0.09 log units) above the measured number; low and high end bracket the measured number.
By their numbers in this assay, from the lowest: compounds 3, 2 and 1 (each within the scatter of the next).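

In this assay, hydrogen in place of fluoro on the six-membered aromatic ring of the fused system gives a 1.1-fold lower number from compound 2 to compound 3 (0.05 log units; within the scatter), so at this position the change leaves no difference that can be read. The same exchange at a different place in the shared core gives a 1.7-fold lower number from compound 1 to compound 3 (0.22 log units; within the scatter), which also stays within the scatter, so neither fluoro, taken alone, separates its compound from compound 3 on these numbers. Nothing at hand bears on why these values lie so close together.

On these data alone, whether a larger group at the first position, such as an amine or a methoxy group, would move the number beyond the scatter remains open. So does the value of a compound carrying both fluoro groups at once.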